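Carboxylic acid to dimethyl amide on a shared core

A few compounds are considered here, and "the series" means these few. Any claim that something is new, unique, unknown or untested is made for them only; others in the source may bear on it.

Measured compounds:
Compound 1, `CCOC(=O)/C=C/c1ccncc1-c1ccc2c(ccn2C)c1`: 144 nM
Compound 2, `O=C(O)CCc1ccncc1-c1ccc2ccccc2c1`: 50.5 nM
Compound 3, `CNC(=O)/C=C/c1ccncc1-c1ccc2cc[nH]c2c1`: 18.6 nM

Of the compounds shown here, three share a core and have been tested in an assay on a protein complex for inhibition of CDK8/Cyclin C (Homo sapiens), with a stated time of 1 h; a lower number here means a stronger inhibitor, a higher number a weaker inhibitor. Compound 1 `CCOC(=O)/C=C/c1ccncc1-c1ccc2c(ccn2C)c1` gives 144 nM. Compound 3 `CNC(=O)/C=C/c1ccncc1-c1ccc2cc[nH]c2c1` gives 18.6 nM. Compound 2 `O=C(O)CCc1ccncc1-c1ccc2ccccc2c1` gives 50.5 nM, the second highest of the three numbers: it sits nearer to compound 3 than to compound 1, and both gaps lie beyond the usual scatter.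

The next compound, compound 4 `CN(C)C(=O)/C=C/c1ccncc1-c1ccc2ccccc2c1`, differs from compound 2 in one place: 2-(dimethylcarbamoyl)ethenyl in place of 2-carboxyethyl on an aromatic carbon. The change sits on an aromatic carbon of a six-membered aromatic ring with one nitrogen, ortho to a large group and opposite the ring nitrogen.

Among the measured compounds shown here, no measured pair shows exactly this change, so the expectation rests on the three values alone. The amide-bearing compound 3 gives the lowest number with 18.6 nM, which suggests an amide is tolerated, yet compound 3 also has a different core. A step of a 1.3-fold lower number from compound 2 to compound 4 (0.10 log units; within the scatter) is expected, with no confident direction beyond the scatter. Compound 4 is estimated at 40 nM, within a range of 12 nM to 130 nM.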

Compound 4, half-maximal inhibitory concentration: 30.1 nM
Compound 4: the middle estimate sits 1.3-fold (0.12 log units) above what was measured; the measured number falls inside the stated range.
By their numbers in this assay, from the lowest: compounds 3, 4 and 2 (each within the scatter of the next, the first and the last beyond it); then compound 1.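

In this assay, among the compounds shown here, the step of a 1.7-fold lower number from compound 2 to compound 4 (0.22 log units; within the scatter) gives the first direct reading at this position, on an aromatic carbon opposite the ring nitrogen. The entering 2-(dimethylcarbamoyl)ethenyl has no hydrogen-bond donor and the leaving 2-carboxyethyl has one, yet the two compounds stay within the scatter of each other, so on this core the swap leaves the number essentially in place. No measurement here explains this result.

The step alters the end group and the double bond of the chain together, and a compound carrying only one of these alterations, such as 2-(dimethylcarbamoyl)ethyl or 2-carboxyethenyl, would be needed to separate the two. On these data alone, how an amine or a longer chain at this position would compare also stays open.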